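Working notes on a fluorophenyl sulfonamide side chain

The source may report more compounds than this note shows. Statements on the series, on what has been measured and on what is new or still open speak of the compounds shown alone.

Measured in a functional assay on LOX IMVI cells (Homo sapiens) for inhibition, read by sulforhodamine B assay, with a stated time of 48 h; on this read-out lower numbers stand for stronger inhibition and higher numbers for weaker inhibition:
- compound 1 `CN1CCCN(CCNc2nccc(-c3c(-c4cccc(O)c4)nc4sccn34)n2)S1(=O)=O`: 4360 nM
- compound 2 `O=S(=O)(NCCCNc1nccc(-c2c(-c3cccc(O)c3)nc3sccn23)n1)c1cccc(F)c1`: 1910 nM

Of the two numbers in this assay, compound 2 has the lower, at 1910 nM. For the measured compounds named here, the next compound, compound 3 `O=S(=O)(NCCNc1nccc(-c2c(-c3cccc(O)c3)nc3sccn23)n1)c1ccc(F)cc1`, keeps the shared core and has no measurement yet. Its difference from compound 2 is ((4-fluorophenyl)sulfonyl)amino in place of (((3-fluorophenyl)sulfonyl)amino)methyl on a saturated chain carbon, two bonds along the chain from a nitrogen on an aromatic ring. In words, ((4-fluorophenyl)sulfonyl)amino stands in place of (((3-fluorophenyl)sulfonyl)amino)methyl on a saturated chain carbon, two bonds along the chain from a nitrogen on an aromatic ring.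

Going by the values given here, only one measured step bears on this, and only indirectly. The step of a 2.3-fold lower number from compound 1 to compound 2 (0.36 log units; beyond the scatter) exchanged a whole group on the same chain and was modest, though beyond the scatter. Among the compounds with values here, no measured pair isolates the fluorine position or the loss of the methyl unit, so the data give no direction. A change this limited is therefore expected to give a small step, probably none beyond the scatter. The expected result is a 1.2-fold higher number from compound 2 to compound 3 (0.06 log units; within the scatter). For compound 3 the estimated value is 2200 nM, with an expected range of 800 nM to 6000 nM.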

Compound 3, half-maximal inhibitory concentration: 4110 nM
For compound 3 the middle estimate is 1.9-fold (0.27 log units) below the measured one; the range from low to high includes it.
By their numbers in this assay, from the lowest: compound 2; then compounds 3 and 1 (each within the scatter of the next).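

In this assay, exchanging (((3-fluorophenyl)sulfonyl)amino)methyl for ((4-fluorophenyl)sulfonyl)amino on the saturated chain carbon gives a 2.2-fold higher number from compound 2 to compound 3 (0.33 log units; beyond the scatter), a modest step, so this position responds to a change within the fluorophenyl sulfonamide groups and not only to the exchange of a whole group. The lower number seen with compound 2 therefore does not extend to every fluorophenyl sulfonamide side chain: a 1.1-fold lower number from compound 1 to compound 3 (0.03 log units; within the scatter), so here ((4-fluorophenyl)sulfonyl)amino cannot be told apart from the group carried by compound 1. Nothing measured on these compounds accounts for the step.

The step from compound 2 to compound 3 moves the fluorine and removes the methyl unit together, so its size cannot be assigned to either change; ((3-fluorophenyl)sulfonyl)amino and (((4-fluorophenyl)sulfonyl)amino)methyl at this place would separate the two. Also open, going by these compounds, is whether the fluorine or the sulfonyl matters at all, which an unsubstituted phenylsulfonyl group or a benzamide at the end of the same chain would begin to address.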